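Shifting the methoxy group on the aryl substituent of compound 2

The compounds below may be only part of what the source reports. "The series", "measured", "known", "first", "only" and "open" are said of these compounds alone.

Three compounds sharing one core were tested in a functional assay on Ehrlich cells (Mus musculus) for cytotoxicity, tested at 50 ug/mL; a higher number here means a stronger effect of the compound at the concentration tested, a lower number a weaker effect. Compound 1 `COc1cc(N2C(N)=C(C#N)C(c3c(O)ccc4ccccc34)C3=C2CC(C)(C)CC3=O)cc(OC)c1OC` gives 15%. Compound 2 `COc1ccccc1C1C(C#N)=C(N)N(c2cc(OC)c(OC)c(OC)c2)C2=C1C(=O)CC(C)(C)C2` gives 70%, and compound 3 `COc1cc(N2C(N)=C(C#N)C(/C=C/c3ccccc3)C3=C2CC(C)(C)CC3=O)cc(OC)c1OC` gives 30%. Compound 2 therefore stands highest of the three: a number 55 percentage points higher from compound 1 to compound 2 (beyond the scatter) and a number 40 percentage points lower from compound 2 to compound 3 (beyond the scatter), both beyond the scatter, while a number 15 percentage points higher from compound 1 to compound 3 (beyond the scatter).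

Compound 4 `COc1ccc(C2C(C#N)=C(N)N(c3cc(OC)c(OC)c(OC)c3)C3=C2C(=O)CC(C)(C)C3)cc1` differs from compound 2 in one place: 4-methoxyphenyl in place of 2-methoxyphenyl on a saturated ring carbon. Among the measured compounds shown here, no measured step moves the methoxy group within the phenyl ring; the two steps that touch this saturated ring carbon, from compound 1 to compound 2 and from compound 2 to compound 3, each replace the whole group and each were large. They show that this position is sensitive, but give no direct guide to a change that keeps the same atoms joined differently. Compound 4 is therefore expected to stay nearer compound 2 than the other two, with some drop as the more likely outcome, so the step from compound 2 to compound 4 is estimated at a number 15 percentage points lower from compound 2 to compound 4 (beyond the scatter). Compound 4 is expected to give about 55% in this assay, within a range from 30% to 80%.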

Compound 4, a percentage reported as activity, at one concentration (the size of the read-out at that concentration, not a potency): 11%
Compound 4: middle estimate off by 44 percentage points, on the high side; measured number below the stated range.
By their numbers in this assay, from the lowest: compounds 4 and 1 (each within the scatter of the next); then compound 3; then compound 2.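

In this assay, the saturated ring carbon proves sensitive not only to replacing the whole group but also to where the methoxy group sits on the phenyl ring: with the same atoms and the same counted features, a number 59 percentage points lower from compound 2 to compound 4 (beyond the scatter), a large step like those that replace the whole group. The high reading of compound 2 therefore belongs to the 2-methoxyphenyl group in particular and not to a methoxyphenyl group as such, since the 4-methoxyphenyl group gives a number 19 percentage points lower from compound 3 to compound 4 (beyond the scatter) and stands level with the 2-hydroxynaphthalen-1-yl group, a number 4 percentage points lower from compound 1 to compound 4 (within the scatter). Nothing available here explains why moving the methoxy group has so large an effect.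

The compounds shown leave open whether the reading of compound 2 depends on the methoxy group itself or would persist with an ethoxy group, a methyl group or a chlorine atom in its place on the phenyl ring. They also leave open whether this gap between compound 2 and compound 4 would hold at other concentrations, as each read-out comes from a single concentration and is not a potency.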